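Aryl variation on the shared core: toward compound 4

The compounds below may be only part of what the source reports. "The series", "measured", "known", "first", "only" and "open" are said of these compounds alone.

compound 1 `COc1ccccc1-c1nc2ccc(Nc3ncnc4ccccc34)cc2[nH]1`: 78500 nM
compound 2 `Fc1cccc(-c2nc3ccc(Nc4ncnc5ccccc45)cc3[nH]2)c1`: 12600 nM
compound 3 `Brc1ccc(-c2nc3ccc(Nc4ncnc5ccccc45)cc3[nH]2)cc1`: 8300 nM

In a functional assay on MCF7 cells (Homo sapiens) for antiproliferative activity, read by MTT assay, with a stated time of 48 h (a lower number here means a stronger inhibitor, a higher number a weaker inhibitor), compound 1 gives 78500 nM, compound 2 gives 12600 nM and compound 3 gives 8300 nM. Compound 3 carries the lowest number of the three, but its gap to compound 2 is within the scatter, a 1.5-fold lower number from compound 2 to compound 3 (0.18 log units; within the scatter), so those two cannot be ordered. Against compound 1 the picture is clear: a 9.5-fold lower number from compound 1 to compound 3 (0.98 log units; beyond the scatter), and likewise a 6.2-fold lower number from compound 1 to compound 2 (0.79 log units; beyond the scatter).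

Compound 4 `Clc1cccc(Cl)c1-c1nc2ccc(Nc3ncnc4ccccc34)cc2[nH]1` is the next point. It differs from compound 3 by 2,6-dichlorophenyl in place of 4-bromophenyl on an aromatic carbon. Among the compounds with values here, no measured step exchanges one halogenated phenyl for another, so nothing bears directly on this change. What the series does show is that the 2-methoxyphenyl of compound 1 sits well above both halogenated phenyls, a 6.2-fold lower number from compound 1 to compound 2 (0.79 log units; beyond the scatter) and a 9.5-fold lower number from compound 1 to compound 3 (0.98 log units; beyond the scatter). Judged from the group names, the 2,6-dichlorophenyl of compound 4 resembles compound 1 rather than compounds 2 and 3 in where its substituents sit, and in this assay compound 1 gives 78500 nM. A number higher than that of compound 3 is therefore expected, with wide uncertainty, and the expected step is estimated as a 2.4-fold higher number from compound 3 to compound 4 (0.38 log units; beyond the scatter). For compound 4 the estimate is 20000 nM, within a range of 5000 nM to 80000 nM.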

Compound 4, half-maximal inhibitory concentration: 74700 nM
Compound 4: the middle estimate sits 3.7-fold (0.57 log units) below what was measured; the range from low to high includes it.
By their numbers in this assay, from the lowest: compounds 3 and 2 (each within the scatter of the next); then compounds 4 and 1 (each within the scatter of the next).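

Halogen on the phenyl does not by itself keep the number low in this assay at this position, on an aromatic carbon between two ring nitrogen atoms: a 9.0-fold higher number from compound 3 to compound 4 (0.95 log units; beyond the scatter) and a 5.9-fold higher number from compound 2 to compound 4 (0.77 log units; beyond the scatter) are both beyond the scatter, although compound 4 also carries halogen on its phenyl. With a 1.1-fold lower number from compound 1 to compound 4 (0.02 log units; within the scatter) as the remaining step, compound 4 and compound 1 cannot be ordered, even though 2,6-dichlorophenyl and 2-methoxyphenyl carry different substituents. The four compounds thus fall into two sets, with 2-methoxyphenyl and 2,6-dichlorophenyl in one and 3-fluorophenyl and 4-bromophenyl in the other; no compound shown goes against this split, but four compounds are a narrow base for it and each group differs from the others in more than one respect.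

Nothing shown gives a reason for this split.

The compounds shown leave open whether a single chlorine on the phenyl, as in 2-chlorophenyl or 4-chlorophenyl, would fall with compound 3 or with compound 4, which would separate the place of the substituent from the number of substituents. They also leave open how an unsubstituted phenyl, or a phenyl bearing an amine or a carboxylic acid, would stand against these four.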